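A few compounds are considered here, and "the series" means these few. Any claim that something is new, unique, unknown or untested is made for them only; others in the source may bear on it.

Measured compounds:
compound 1 `c1ccc(NCCNc2ncnc3[nH]cnc23)cc1` — 132000 nM
compound 2 `Cc1ccc(S(=O)(=O)n2cnc3c(N4CCC(C)CC4)ncnc32)cc1` — 14600 nM

In a functional assay on HCT-116 cells (Homo sapiens) for cytotoxicity, read by sulforhodamine B assay, with a stated time of 72 h (a higher number here means a weaker inhibitor, a lower number a stronger inhibitor), compound 2 gives 14600 nM, the lowest of the two numbers, and compound 1 gives 132000 nM, a gap that lies beyond the scatter. Compound 3 `Cc1ccc(S(=O)(=O)n2cnc3c(NCCC4C=CCCC4)ncnc32)cc1` differs from compound 2 in one place: (2-(cyclohex-2-en-1-yl)ethyl)amino in place of 4-methylpiperidin-1-yl on an aromatic carbon. Among the compounds with values here, no measured pair shows this kind of change, so the size of the step is uncertain. A secondary amine with a flexible chain replaces a cyclic tertiary amine, and the step of a 1.5-fold higher number from compound 2 to compound 3 (0.18 log units; within the scatter) is expected to be small, leaning toward a weaker inhibitor. Compound 3 is therefore estimated at 22000 nM, with a range from 6000 nM to 80000 nM.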

Compound 3, half-maximal inhibitory concentration: 8700 nM
For compound 3 the middle estimate is 2.5-fold (0.40 log units) above the measured one; measured number inside the range.
By their numbers in this assay, from the lowest: compounds 3 and 2 (each within the scatter of the next); then compound 1.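

In this assay, placing (2-(cyclohex-2-en-1-yl)ethyl)amino instead of 4-methylpiperidin-1-yl on this aromatic carbon gives a 1.7-fold lower number from compound 2 to compound 3 (0.22 log units; within the scatter), a step that stays within the scatter. This position therefore accepts an amine with a hydrogen-bond donor and a ring held on a chain as well as a ring attached directly through its nitrogen, with no separable difference in the number. Nothing available explains this match.

From the compounds shown here alone, whether a morpholine ring or a carboxylic acid on the chain would move the number beyond the scatter remains open. Compound 1 differs from both compounds in more than one place, so the contribution of the 4-methylphenylsulfonyl group cannot be read.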